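Removing One Methoxy Group: A Large Step Repeated?

A few compounds are considered here, and "the series" means these few. Any claim that something is new, unique, unknown or untested is made for them only; others in the source may bear on it.

Three measured compounds come first. Compound 1 `COc1ccc(-c2cc(/C=C/C(=O)c3ccc(N)cc3)[nH]n2)cc1`, compound 2 `COc1ccc(-c2cc(/C=C/C(=O)c3ccc(N)cc3)[nH]n2)cc1OC` and compound 3 `COc1cc(C(=O)/C=C/c2cc(-c3cc(OC)c(OC)c(OC)c3)n[nH]2)cc(OC)c1OC` were all tested in a functional assay on HCT-116 cells (Homo sapiens) for cytotoxicity, read by sulforhodamine B assay, with a stated time of 48 h, tested at 100 uM; on this read-out higher numbers stand for a weaker effect at the one concentration tested and lower numbers for a stronger effect. In this assay compound 1 gives -15%, compound 2 gives -89%, and compound 3 gives -88%.

Compound 2 and compound 1 differ in one place: hydrogen in place of methoxy on an aromatic carbon. That change made a large step, a number 74 percentage points higher from compound 2 to compound 1 (beyond the scatter), so a single methoxy group mattered a great deal here. Compound 3 and compound 2 have different cores; the difference between the two cores is not broken down here, and their values in this assay lie within the scatter of each other.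

Compound 4 `COc1ccc(-c2cc(/C=C/C(=O)c3cc(OC)c(OC)c(OC)c3)[nH]n2)cc1OC` has not yet been measured. It differs from compound 3 by the same kind of change: hydrogen in place of methoxy on an aromatic carbon. The surroundings are not identical, though: in compound 3 the carbon that loses its methoxy is also meta to a methoxy group, which the corresponding carbon in compound 2 is not.

Going by the values given here, because a number 74 percentage points higher from compound 2 to compound 1 (beyond the scatter) was a large step in the only measured example of this change, a step in the same direction is expected for compound 4, though with less confidence, since the surroundings differ and only one precedent exists. The step from compound 3 to compound 4 in this assay is estimated as a number 53 percentage points higher from compound 3 to compound 4 (beyond the scatter). Compound 4 is therefore expected to give about -35%, most likely between -75% and 0%.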

Compound 4, a percentage reported as activity, at one concentration (the size of the read-out at that concentration, not a potency): -61%
For compound 4 the middle estimate is 26 percentage points above the measured one; the measured number falls inside the stated range.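

In this assay the change kept its direction on the second core, with a number 27 percentage points higher from compound 3 to compound 4 (beyond the scatter), so removing a methoxy group again left a weaker effect at the one concentration tested. The size of the step did not carry over, however, and the two cores gave clearly different steps: the same change on two cores in this assay, a number 74 percentage points higher (beyond the scatter) from compound 2 to compound 1 and a number 27 percentage points higher (beyond the scatter) from compound 3 to compound 4, 47 percentage points apart, beyond the scatter of two such steps. For this series, a large step seen on one core was therefore a poor guide to the size of the step on another, although two examples cannot show which difference between the cores sets that size, or whether the direction would hold on a third core.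

The compounds shown replace methoxy only with hydrogen, so it remains open what a hydroxyl group, a fluorine atom or a longer chain such as ethoxy would do in its place. Each read-out also comes from a single concentration, which shows only a stronger or weaker effect at that concentration and leaves open whether the gap between the two steps would still appear at lower concentrations, where the effects may be less extreme.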